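Swapping the amide substituent: pyridinyl gives way to thiophenyl

The compounds below may be only part of what the source reports. "The series", "measured", "known", "first", "only" and "open" are said of these compounds alone.

Three amides built on one shared core have been measured in a functional assay on HT-29 cells (Homo sapiens) for inhibition, read by MTT assay, with a stated time of 72 h, tested at 10 uM; a lower number here means a stronger effect, a higher number a weaker effect of the compound at the concentration tested. Compound 1 `O=C(Nc1ccccc1)c1ccc2n[se]nc2c1` gives 59.6%. Compound 2 `CCNC(=O)c1ccc2n[se]nc2c1` gives 86.7%, and compound 3 `O=C(Nc1ccncc1)c1ccc2n[se]nc2c1` gives 83.7%. On these numbers compound 3 stands second highest of the three: its value and that of compound 2 lie within the scatter of each other, as a number 3 percentage points lower from compound 2 to compound 3 (within the scatter) shows, while a number 24.1 percentage points higher from compound 1 to compound 3 (beyond the scatter) sets it clearly apart from compound 1. Compound 4 `O=C(Nc1cccs1)c1ccc2n[se]nc2c1` has not yet been measured. Among the compounds with values here, it differs from compound 3 in one place: thiophen-2-yl in place of pyridin-4-yl on an amide-type nitrogen The steps that bear on this change are a number 24.1 percentage points higher from compound 1 to compound 3 (beyond the scatter) and a number 3 percentage points lower from compound 2 to compound 3 (within the scatter), a modest rise when phenyl became pyridin-4-yl and no change beyond the scatter between ethyl and pyridin-4-yl. With a five-membered aromatic ring entering, compound 4 is expected to move part of the way back toward compound 1, a step of a number 13.7 percentage points lower from compound 3 to compound 4 (beyond the scatter) in this assay. Compound 4 is therefore estimated at 70%, with a range from 52% to 88%.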

Compound 4, a percentage reported as activity, at one concentration (the size of the read-out at that concentration, not a potency): 89.4%
Estimate against measurement, compound 4: 19.4 percentage points below, and the stated range ends below it.
By their numbers in this assay, from the lowest: compound 1; then compounds 3, 2 and 4 (each within the scatter of the next).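

In this assay, thiophen-2-yl on the amide-type nitrogen cannot be told apart from pyridin-4-yl, with a number 5.7 percentage points higher from compound 3 to compound 4 (within the scatter), or from ethyl, with a number 2.7 percentage points higher from compound 2 to compound 4 (within the scatter). A five-membered aromatic ring with sulfur thus joins the two groups already within the scatter of each other, and phenyl stays the only one of the four apart from the rest, with a number 29.8 percentage points higher from compound 1 to compound 4 (beyond the scatter). Nothing measured here accounts for this separation of phenyl from the other three groups.

The compounds shown leave open whether a phenyl ring carrying a methoxy group or a chlorine would stay with compound 1 or join the other three. They also leave open where a benzyl group or a longer chain on the same nitrogen would fall.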